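This account rests on a few compounds, and the source may have more. Where it says the series, first, only, none or still open, it means among the compounds named here.

Of the compounds shown here, three share one core and have been measured in a physicochemical assay for solubility; a higher number here means a more soluble compound, a lower number a less soluble compound. Compound 3 `CCCC(=O)n1c(=S)[nH]c2ccccc21` gives 190000 nM and stands highest of the three, though its nearest neighbour compound 1 `O=C(CCc1ccccc1)n1c(=S)[nH]c2ccccc21`, which gives 100000 nM, lies within the scatter of it; compound 2 `CCCCCC(=O)n1c(=S)n(C(C)=O)c2ccccc21` gives 49000 nM and sits clearly lower.

Compound 4 `CCCCCC(=O)n1c(=S)[nH]c2ccccc21` has not yet been measured. It differs from compound 3 in one place: ethyl in place of hydrogen on a saturated chain carbon, three bonds along the chain from a carbonyl carbon. Going by the values given here, the only measured step that touches the same part of the molecule is a 1.9-fold higher number from compound 1 to compound 3 (0.28 log units; within the scatter), where a larger group gave way to a smaller one and the numbers hardly moved. Compound 2 carries the same chain as compound 4 but with an extra group on the core, so its value shows only that a chain of this length can still reach a moderate number.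

On this basis a small downward step, possibly within the scatter, is expected, written as a 1.9-fold lower number from compound 3 to compound 4 (0.28 log units; within the scatter). Compound 4 is therefore estimated at 100000 nM, with a range from 40000 nM to 250000 nM.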

Compound 4, solubility: 170000 nM
Compound 4: the middle estimate sits 1.7-fold (0.23 log units) below what was measured; the range from low to high includes it.
By their numbers in this assay, from the lowest: compound 2; then compounds 1, 4 and 3 (each within the scatter of the next).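

In this assay, ethyl in place of hydrogen on a saturated chain carbon, three bonds along the chain from a carbonyl carbon, gives a 1.1-fold lower number from compound 3 to compound 4 (0.05 log units; within the scatter), and swapping phenyl for propyl gives a 1.7-fold higher number from compound 1 to compound 4 (0.23 log units; within the scatter), so this part of the chain has so far tolerated these swaps without a change beyond the scatter. Going by these compounds alone, the one clear step comes from the core instead: hydrogen in place of acetyl on an aromatic nitrogen gives a 3.5-fold higher number from compound 2 to compound 4 (0.54 log units; beyond the scatter), which isolates that group for the first time. No measurement is available to explain either result.

Open, going by these compounds, is whether a much longer chain, or a chain ending in an amine or a carboxylic acid, would also stay within the scatter. Also open, on these data alone, is whether acetyl on the aromatic nitrogen would give a step of similar size with a butanoyl chain in place of the hexanoyl chain.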